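This account rests on a few compounds, and the source may have more. Where it says the series, first, only, none or still open, it means among the compounds named here.

In a toxicity assay on Vero C1008 cells (Chlorocebus sabaeus) for cytotoxicity, read by MTT assay, with a stated time of 48 h (on this read-out higher numbers stand for lower toxicity in this test and lower numbers for higher toxicity in this test), compound 1 (`O=C(Nc1ccc([N+](=O)[O-])cc1)c1cc(Cl)ccc1O`) gives 2280 nM while compound 2 (`O=C(Nc1cccc([N+](=O)[O-])c1)c1cc(Cl)ccc1O`) gives 3530 nM and compound 3 (`O=C(Nc1ccc([N+](=O)[O-])c(Cl)c1)c1cc(Cl)ccc1O`) gives 1510 nM on the same read-out. On these numbers compound 1 lies within the scatter of both compound 2 and compound 3, so it stands clearly apart from neither. Compound 4 (`O=C(Nc1ccc(C(F)(F)F)cc1)c1cc(Cl)ccc1O`) has no number yet. Its change from compound 1 is trifluoromethyl in place of nitro on an aromatic carbon, para to a large group (trifluoromethyl in place of nitro on an aromatic carbon). Within the data shown here, no measured pair makes this exchange, so the support is indirect. Among the measured compounds shown here, the only measured step (a 1.5-fold lower number from compound 1 to compound 3 (0.18 log units; within the scatter)) is a different change, chloro in place of hydrogen on an aromatic carbon, and it stays within the scatter. In this assay no shift beyond the scatter is therefore expected, and the estimated step (a 1.1-fold higher number from compound 1 to compound 4 (0.04 log units; within the scatter)) has no firm direction. For compound 4 the estimated value is 2500 nM with an expected range from 1100 nM to 5500 nM on this read-out.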

Compound 4, half-maximal cytotoxic concentration: 1180 nM
Estimate against measurement, compound 4: 2.1-fold (0.33 log units) above; the measured number falls inside the stated range.
By their numbers in this assay, from the lowest: compounds 4, 3, 1 and 2 (each within the scatter of the next, the first and the last beyond it).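

In this assay the exchange of nitro for trifluoromethyl on an aromatic carbon, para to a large group, gives a 1.9-fold lower number from compound 1 to compound 4 (0.29 log units; within the scatter), so this step stays within the scatter. All earlier compounds carried nitro, and compound 4 now shows that the number stays within the scatter of compound 1 without it, even though nitro counts 2 hydrogen-bond acceptors and trifluoromethyl 0. Nothing at hand bears on what lies behind this step. Going by these compounds, it remains open whether an amine, a carboxylic acid or a longer chain at this same place would carry the number beyond the scatter. On these data alone, it also remains open how trifluoromethyl would read at the nitro position of compound 2, or together with the added chloro of compound 3.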